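The source may report more compounds than this note shows. Statements on the series, on what has been measured and on what is new or still open speak of the compounds shown alone.

Of the compounds shown here, three sharing one core have been measured in a functional assay on K562 cells (Homo sapiens) for antiproliferative activity, read by MTT assay, with a stated time of 48 h; on this read-out lower numbers stand for stronger inhibition and higher numbers for weaker inhibition. Compound 1 `CCCCc1ccc2c(c1)C(=O)C(=O)N2` carries a butyl group and an unsubstituted amide nitrogen. In this assay compound 1 reaches only the limit of the test, > 10000 nM, which is not a number. Compound 2 `O=C1Nc2ccc(-c3ccc(C(F)(F)F)cc3)cc2C1=O` carries a trifluoromethyl-substituted phenyl ring in place of the butyl group and likewise keeps the amide hydrogen. In this assay compound 2 also stops at the limit, > 10000 nM, again not a number. Compound 3 `COc1ccc(-c2ccc3c(c2)C(=O)C(=O)N3C)cc1` carries a methoxy-substituted phenyl ring and a methyl group on the amide nitrogen. In this assay, for the measured compounds named here, compound 3 gives 4980 nM, the only actual number among the three. Compounds 1 and 2 sit at the limit of > 10000 nM in this assay, at which 2 of the 3 values shown sit, so compound 3 stands alone with a measured value.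

Compound 4 `C=CCN1C(=O)C(=O)c2cc(-c3ccc(OC)cc3)ccc21` has not yet been measured. It differs from compound 3 in one place: vinyl in place of hydrogen on a saturated chain carbon bound to an amide-type nitrogen in a ring. Going by the values given here, no step between two measured compounds is available, so no measured size of change can guide the expectation. The change exchanges a methyl for an allyl group, and a step within the usual scatter, in either direction, is expected: a 1.4-fold lower number from compound 3 to compound 4 (0.15 log units; within the scatter). Compound 4 is therefore expected to give 3500 nM in this assay, with a range from 1200 nM to 10000 nM.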

Compound 4, half-maximal inhibitory concentration: 390 nM
Compound 4: the middle estimate sits 9.0-fold (0.95 log units) above what was measured; measured number outside the range, below it.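

On the saturated chain carbon bound to an amide-type nitrogen in a ring, going from methyl to allyl gives a 13-fold lower number from compound 3 to compound 4 (1.11 log units; beyond the scatter) in this assay. For the compounds shown here, this is the first step in the set that can be read between two measured compounds, and it shows that this place is sensitive to what it carries: a vinyl group of 2 heavy atoms, with no hydrogen-bond donors or acceptors, is enough to move the number beyond the scatter. It remains a single step in a single assay, so it sets no trend, and no measurement shown gives a reason for its size.

Going by these compounds, whether a propyl group, a benzyl group or a chain ending in an amine would act in the same way stays open, and so does whether the double bond itself matters. Compound 1 and compound 2 cannot settle what the amide hydrogen does, as each differs from compound 3 and compound 4 in more than one place and reaches only a limit of the test, not a number: the limit of > 10000 nM in this assay, at which 2 of the 4 values shown sit.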